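The source may report more compounds than this note shows. Statements on the series, on what has been measured and on what is new or still open speak of the compounds shown alone.

Series notes. For the measured compounds named here, compound 1 `Cn1cnc2c(Nc3ccccc3)ncnc21` is one of three compounds measured in an assay on Cortex for binding affinity to adenosine receptor A1 (Rattus norvegicus), read by radioligand binding (on this read-out lower numbers stand for stronger inhibition and higher numbers for weaker inhibition), where compound 1 gives 6900 nM. Compound 3 `c1ccc(Nc2ncnc3c2ncn3-c2ccccc2)cc1` gives 6900 nM, and compound 2 `c1nc(NC2CCCC2)c2ncn(C3CCCC3)c2n1` gives 1200 nM. On these numbers compound 1 stands level with compound 3, the two together the highest of the three; compound 2 sits furthest from compound 1, with a lower number beyond the scatter. Going by the values given here, the only pair differing in a single place, phenyl in place of methyl on an aromatic nitrogen, gave no change at the digits printed from compound 1 to compound 3 (within the scatter).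

Compound 4 `Cn1cnc2c(Nc3ccccc3)nc(Cl)nc21` has not yet been measured. It differs from compound 1 by chloro in place of hydrogen on an aromatic carbon. Among the compounds with values here, no measured step touches this group or this carbon; the step from compound 1 to compound 3 alters the substituent on the aromatic nitrogen only and does not bear on the present change. With nothing in the series to fix the size, the expectation for compound 4 rests on compound 1 at 6900 nM as the anchor. The step expected a 1.7-fold lower number from compound 1 to compound 4 (0.24 log units; within the scatter) is small, a modest lowering if anything. Compound 4 is estimated at 4000 nM in this assay, with a range from 1200 nM to 14000 nM.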

Compound 4, inhibition constant: 7000 nM
For compound 4 the middle estimate is 1.8-fold (0.24 log units) below the measured one; low and high end bracket the measured number.
By their numbers in this assay, from the lowest: compound 2; then compounds 1, 3 and 4 (each within the scatter of the next).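

In this assay, chloro in place of hydrogen on the aromatic carbon between two ring nitrogen atoms gives a 1.0-fold higher number from compound 1 to compound 4 (0.01 log units; within the scatter), so this carbon of the core of compound 1 takes a chlorine atom without a step beyond the scatter. For the compounds shown here, this is the first reading at this carbon, as the earlier step from compound 1 to compound 3 altered only the substituent on the aromatic nitrogen; both single-place steps now at hand, one at that nitrogen and one at this carbon, lie within the scatter. No supporting data bear on this result, so it stands as an observation without an explanation.

A single chloro group at one carbon does not tell whether an amine, a methoxy group or a longer chain at the same carbon would also stay within the scatter of compound 1. On these data alone, it also remains open whether chloro in place of hydrogen at this carbon would read the same on compound 2 or on compound 3, whose other substituents differ from those of compound 1.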